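The compounds below may be only part of what the source reports. "The series", "measured", "known", "first", "only" and "open" are said of these compounds alone.

Within the data shown here, in a functional assay on MCF7 cells (Homo sapiens) for inhibition, read by MTT assay, with a stated time of 24 h (on this read-out lower numbers stand for stronger inhibition of growth and higher numbers for weaker inhibition of growth), compound 1 (`COc1ccc2c(c1)c(-c1nc3ccccc3n1C(=O)c1ccccc1OC)cn2C`) gives 23900 nM and compound 2 (`COc1ccc2c(c1)c(-c1nc3ccccc3n1C(=O)c1ccc(OC)c(OC)c1)cn2C`) gives 6300 nM, so compound 2 holds the lower of the only two numbers available. Compound 3 (`COc1ccc2c(c1)c(-c1nc3ccccc3n1C(=O)c1cccc(Br)c1)cn2C`) keeps the shared core but carries a different group on the carbonyl carbon: 3-bromophenyl in place of 3,4-dimethoxyphenyl on a carbonyl carbon. In words, 3-bromophenyl stands in place of 3,4-dimethoxyphenyl. Among the measured compounds shown here, one measured step bears on this, as it changes the group at the same place. Replacing 2-methoxyphenyl with 3,4-dimethoxyphenyl gave a 3.8-fold lower number from compound 1 to compound 2 (0.58 log units; beyond the scatter), a modest step beyond the usual scatter. That single step says nothing direct about a bromine-bearing ring, so the direction of the next step is uncertain. Even so, a step of similar modest size seems a reasonable expectation, with the number more likely to rise than to fall from the lower of the two values. The expected change is a 1.6-fold higher number from compound 2 to compound 3 (0.20 log units; within the scatter). For compound 3 the estimated value in this assay is 10000 nM, with an expected range from 3000 nM to 32000 nM.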

Compound 3, concentration for 50% growth inhibition: 52700 nM
Compound 3: the middle estimate sits 5.3-fold (0.72 log units) below what was measured; the measured number lies above the stated range.
By their numbers in this assay, from the lowest: compound 2; then compound 1; then compound 3.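

In this assay, the group on the carbonyl carbon can push the number up as well as down: 3-bromophenyl in place of 3,4-dimethoxyphenyl gives an 8.4-fold higher number from compound 2 to compound 3 (0.92 log units; beyond the scatter), and this step is beyond the usual scatter. The comparison with the other methoxy-bearing ring points the same way, since 3-bromophenyl in place of 2-methoxyphenyl gives a 2.2-fold higher number from compound 1 to compound 3 (0.34 log units; beyond the scatter), so among these three compounds both rings carrying methoxy groups give lower numbers than the bromine-bearing ring, with no compound going against that order. The 3,4-dimethoxyphenyl group that leaves has 2 hydrogen-bond acceptors and the 3-bromophenyl group that enters has 0, but nothing measured here explains why the number rises.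

These three compounds cannot separate the effect of adding bromine from that of losing the methoxy groups, since both changes arrive together in a single swap, and a single bromine-bearing ring cannot show whether the place of the bromine on that ring matters. Going by these compounds, it also remains open how the number would respond to a ring carrying an amine or a carboxylic acid, or to a longer chain on the same carbonyl carbon in place of the ring.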